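Trifluoromethyl for methylbenzyl on the saturated ring

A few compounds are considered here, and "the series" means these few. Any claim that something is new, unique, unknown or untested is made for them only; others in the source may bear on it.

Measured compounds:
Compound 1 `Cc1ccc(Nc2nc(C(F)(F)F)ccc2CNC(=O)C(C)c2ccc(NS(C)(=O)=O)c(F)c2)cc1C` gives 39.3 nM in a functional assay on CHO-K1 cells for antagonist activity at transient receptor potential cation channel subfamily V member 1 (Homo sapiens), read by FLIPR; on this read-out higher numbers stand for weaker inhibition and lower numbers for stronger inhibition.
Compound 2 `CC(C(=O)NCc1ccc(C(F)(F)F)nc1NCc1ccc(Cl)cc1)c1ccc(NS(C)(=O)=O)c(F)c1` gives 65.7 nM in this assay.
Compound 3 `Cc1ccc(CC2CCN(c3nc(C(F)(F)F)ccc3CNC(=O)C(C)c3ccc(NS(C)(=O)=O)c(F)c3)CC2)cc1` gives 0.2 nM in this assay.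

Compound 3 stands lowest of the three numbers; compound 1 is nearest, and compound 2 is furthest. Among the compounds with values here, the only single-site step among the measured compounds is a 1.7-fold higher number from compound 1 to compound 2 (0.22 log units; within the scatter), and it concerns the group on the aromatic nitrogen, not the saturated ring. Compound 4 `CC(C(=O)NCc1ccc(C(F)(F)F)nc1N1CCC(C(F)(F)F)CC1)c1ccc(NS(C)(=O)=O)c(F)c1` differs from compound 3 in one place: trifluoromethyl in place of 4-methylbenzyl on a saturated ring carbon. Within the data shown here, no measured step covers this change, so the expectation rests on the spread of the numbers alone. Compounds 1 and 2, which lack the large group on a saturated ring, sit far above compound 3, so removing that group is expected to move the number upward, though the smaller trifluoromethyl that enters may keep part of the gain. The step from compound 3 to compound 4 is therefore estimated as a 40-fold higher number from compound 3 to compound 4 (1.60 log units; beyond the scatter). In this assay compound 4 is expected to give about 8 nM, with a likely range from 1.5 nM to 40 nM.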

Compound 4, inhibition constant: 0.6 nM
Compound 4: middle estimate off by 13-fold (1.12 log units), on the high side; measured number outside the range, below it.
By their numbers in this assay, from the lowest: compound 3; then compound 4; then compounds 1 and 2 (each within the scatter of the next).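

Swapping the 4-methylbenzyl, with its aromatic ring and 8 heavy atoms, for a trifluoromethyl of 4 heavy atoms on the saturated ring carbon costs little in this assay: the step is a 3.0-fold higher number from compound 3 to compound 4 (0.48 log units; beyond the scatter). So the benzyl ring is not needed for a low number here, and even the small group keeps compound 4 far below the compounds carrying an amino link on the aromatic carbon, with a 110-fold lower number from compound 2 to compound 4 (2.04 log units; beyond the scatter) and a 66-fold lower number from compound 1 to compound 4 (1.82 log units; beyond the scatter). Nothing available explains why either change has this effect.

Going by these compounds, it remains open how much the trifluoromethyl itself contributes, since a plain hydrogen, a methyl or a hydroxyl on the same ring carbon would set its effect apart from that of the saturated ring. On these data alone, whether a longer chain, such as a phenethyl, would match the 4-methylbenzyl also stays unknown.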